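Dimethylcarbamoyl in Place of the Cyanopyridyl Group

The compounds below may be only part of what the source reports. "The series", "measured", "known", "first", "only" and "open" are said of these compounds alone.

Three measured compounds share one core and differ at a single carbon. In an assay for inhibition of Fatty-acid amide hydrolase 1 (Rattus norvegicus) (a lower number here means a stronger inhibitor, a higher number a weaker inhibitor), compound 1 `N#Cc1cccc(-c2cnc(C(=O)CCc3ccc(COc4ccccc4)cc3)o2)n1` gives 0.56 nM, compound 2 `CS(=O)(=O)c1cnc(C(=O)CCc2ccc(-c3ccccc3)cc2)o1` gives 1.2 nM, and compound 3 `N#Cc1cccc(-c2cnc(C(=O)CCc3ccc(-c4ccccc4)cc3)o2)n1` gives 2.9 nM, the highest of the three numbers. The steps of a 5.2-fold higher number from compound 1 to compound 3 (0.71 log units; beyond the scatter) and a 2.4-fold higher number from compound 2 to compound 3 (0.38 log units; beyond the scatter) show the spread. Compound 4 `CN(C)C(=O)c1cnc(C(=O)CCc2ccc(-c3ccccc3)cc2)o1` differs from compound 3 by dimethylcarbamoyl in place of 6-cyanopyridin-2-yl on an aromatic carbon. Among the measured compounds shown here, of the measured steps only the one from compound 2 to compound 3 bears on this change, since it too set a small non-ring group against the 6-cyanopyridin-2-yl, and it was modest in size. A return to a small group is therefore expected to lower the number modestly, as a 1.9-fold lower number from compound 3 to compound 4 (0.29 log units; within the scatter). Compound 4 is expected to give 1.5 nM in this assay, within 0.5 nM to 5 nM.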

Compound 4, inhibition constant: 3 nM
The estimate for compound 4 lay 2.0-fold (0.30 log units) below the measured number; measured number inside the range.
By their numbers in this assay, from the lowest: compound 1; then compound 2; then compounds 3 and 4 (each within the scatter of the next).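

In this assay, dimethylcarbamoyl and 6-cyanopyridin-2-yl on the aromatic carbon next to the ring oxygen cannot be told apart (a 1.0-fold higher number from compound 3 to compound 4 (0.01 log units; within the scatter)), so the ring of the 6-cyanopyridin-2-yl group is not needed to hold this number. The two non-ring groups do separate, with methylsulfonyl giving the lower number (a 2.5-fold higher number from compound 2 to compound 4 (0.40 log units; beyond the scatter)). No measurement shown accounts for this gap.

The compounds shown leave open how a carboxylic acid or a primary amine would read at this carbon. They also leave open whether the gap between methylsulfonyl and dimethylcarbamoyl persists with phenoxymethyl in place of phenyl.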